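Adding a methoxy to compound 3

This account rests on a few compounds, and the source may have more. Where it says the series, first, only, none or still open, it means among the compounds named here.

Compound 1 `COc1ccc(/C=C/C(=O)/C=C/c2cc3ccccc3nc2Cl)c(OC)c1`, compound 2 `COc1ccc(/C=C/C(=O)/C=C/c2cc3ccccc3nc2Oc2ccccc2)c(OC)c1` and compound 3 `COc1ccc(/C=C/C(=O)/C=C/c2cc3ccccc3nc2Oc2ccc(Br)cc2)c(OC)c1` share a core and were measured in a functional assay on DU-145 cells (Homo sapiens) for cytotoxicity, read by MTT assay, with a stated time of 48 h; a lower number here means a stronger inhibitor, a higher number a weaker inhibitor. Compound 1 gives > 10000 nM, which is a limit and not a number. Compound 2 gives > 10000 nM, also a limit. Compound 3 gives > 10000 nM, again a limit, so its place among the three cannot be ranked.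

Compound 4 `COc1cc(OC)c(/C=C/C(=O)/C=C/c2cc3ccccc3nc2Oc2ccc(Br)cc2)c(OC)c1` differs from compound 3 by methoxy in place of hydrogen on an aromatic carbon, turning 2,4-dimethoxyphenyl into 2,4,6-trimethoxyphenyl. Among the compounds with values here, none of the measured steps makes this same change. The nearest are a step that the two limits leave unreadable from compound 2 to compound 3, a step that the two limits leave unreadable from compound 1 to compound 2 and a step that the two limits leave unreadable from compound 1 to compound 3, and none has a size that can be carried over. Within the data shown here, no direction can therefore be read from them, and the only guide is the limit of > 10000 nM in this assay, at which 3 of the 3 values shown sit. A further limit reading in this assay is the likeliest expected outcome. The expected change is a number no higher from compound 3 to compound 4 (the limit leaves the size open), with no clear step beyond the scatter anticipated. Compound 4 is estimated at 10000 nM, within an expected range of 3000 nM to 20000 nM.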

Compound 4, half-maximal inhibitory concentration: > 10000 nM
Compound 4: a limit, no number; the forecaster's own chance of this, stated with the estimate: 60%; the middle value sits exactly at the limit.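

Compound 3 and compound 4 each give only a limit in this assay, not a number, so no step can be read between them. The compounds shown leave open whether the added methoxy, or any other change here, alters the reading at all, and one fact marks that boundary: the limit of > 10000 nM in this assay, at which 4 of the 4 values shown sit.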